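Ester to Alcohol on the Amine Side Chain

The compounds below may be only part of what the source reports. "The series", "measured", "known", "first", "only" and "open" are said of these compounds alone.

Compound 1 `COCC(COC)N(C)c1nc(C)nc2c1nnn2-c1ccc(C(C)C)cc1Br`: 21.3 nM
Compound 2 `CCC(Nc1nc(C)nc2c1nnn2-c1ccc(C(C)C)cc1Br)C(=O)OC`: 19.4 nM

In an in vitro assay on 293-EBNA cells for binding affinity to corticotropin-releasing factor receptor 1 (Homo sapiens) (a higher number here means a weaker inhibitor, a lower number a stronger inhibitor), compound 2 gives 19.4 nM, and compound 1 gives 21.3 nM, the two lying within the scatter of each other. For the measured compounds named here, the single measured step, a 1.1-fold lower number from compound 1 to compound 2 (0.04 log units; within the scatter), exchanges the whole group on the nitrogen of the shared core and stays within the scatter. Compound 3 `CCC(CO)Nc1nc(C)nc2c1nnn2-c1ccc(C(C)C)cc1Br` carries hydroxymethyl in place of methoxycarbonyl on a saturated chain carbon bound to a nitrogen on an aromatic ring and a saturated chain carbon. Going by the values given here, no measured step touches this exact change; the one step that exists shows the shared core accepting a different group at this nitrogen without a shift beyond the scatter. Compound 3 is therefore expected to give 30 nM, between 10 nM and 90 nM. The expected step is a 1.5-fold higher number from compound 2 to compound 3 (0.19 log units; within the scatter), within the scatter.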

Compound 3, inhibition constant: 25.3 nM
Compound 3: the middle estimate sits 1.2-fold (0.07 log units) above what was measured, within the range that was stated.
By their numbers in this assay, from the lowest: compounds 2, 1 and 3 (each within the scatter of the next).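

In this assay the exchange of methoxycarbonyl for hydroxymethyl gives a 1.3-fold higher number from compound 2 to compound 3 (0.12 log units; within the scatter) and shows that this chain carbon takes a hydrogen-bond donor in place of the ester without a shift beyond the scatter. The larger exchange of the whole group on the aromatic carbon gives a 1.2-fold higher number from compound 1 to compound 3 (0.07 log units; within the scatter) and likewise stays within the scatter. No evidence is available to explain this result.

The compounds shown leave open whether a carboxylic acid or an amine on this chain carbon would also stay within the scatter. From the compounds shown here alone, a longer chain in place of the hydroxymethyl also remains untested here.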